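Iodo to ethynyl: working notes on compound 3

A few compounds are considered here, and "the series" means these few. Any claim that something is new, unique, unknown or untested is made for them only; others in the source may bear on it.

Measured so far:
- compound 1 `NC(=O)c1nn([C@@H]2O[C@H](CO)[C@@H](O)[C@H]2O)cc1I`: > 300000 nM (a limit)
- compound 2 `COC(=O)c1nn([C@@H]2O[C@H](CO)[C@@H](O)[C@H]2O)cc1I`: 4000 nM

In a functional assay on HEL 299 cells (Homo sapiens) (on this read-out higher numbers stand for weaker inhibition and lower numbers for stronger inhibition), compound 1 gives > 300000 nM, which is a limit of the assay and not a number. This leaves a single reference point on that side of the series: the limit of > 300000 nM in this assay, at which 1 of the 2 values shown sits.

Compound 3 `C#Cc1cn([C@@H]2O[C@H](CO)[C@@H](O)[C@H]2O)nc1C(N)=O` keeps the carbamoyl group of compound 1 and differs in one substituent: ethynyl in place of iodo on an aromatic carbon.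

For the measured compounds named here, the only measured step, an at least 75-fold lower number from compound 1 to compound 2 (1.87 log units; beyond the scatter), is methoxy in place of amino on a carbonyl carbon, so it does not test ethynyl in place of iodo. Going by the values given here, it shows only that one single change to compound 1 can produce a measurable number, as compound 2 does at 4000 nM. Among the compounds with values here, no measured step gives a size for the present change. A moderate step towards a lower number is tentatively expected in this assay, though compound 3 may also stay at the limit. The expected change is an at least 6.0-fold lower number from compound 1 to compound 3 (0.77 log units; beyond the scatter). Compound 3 is expected at 50000 nM, with an estimated range from 3000 nM to 300000 nM.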

Compound 3, half-maximal inhibitory concentration: 235000 nM
The estimate for compound 3 lay 4.7-fold (0.67 log units) below the measured number; the range from low to high includes it.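

Compound 1 stands at a limit of the assay in this assay, > 300000 nM, and that limit is not a number. With ethynyl in place of iodo on the aromatic carbon next to the ring atom that bears a carbamoyl group, the step is an at least 1.2-fold lower number from compound 1 to compound 3 (0.10 log units; that floor lies within the scatter), so the carbamoyl side of the series now has a measured value at this position, while the floor of the step alone does not establish a real difference between the two groups. With one reference point still a limit, the size of this change has only a floor and no upper bound: the limit of > 300000 nM in this assay, at which 1 of the 3 values shown sits.

The compounds shown leave open whether ethynyl in place of iodo would have a step of similar size with methoxy on the carbonyl carbon, as in compound 2, where the iodo compound gives a measured number rather than a limit. They also leave open how an amine, a nitrile or a longer alkyne chain on this aromatic carbon would read in this assay, so no trend across substituents at this position can be stated from iodo and ethynyl alone.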